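Swapping One Small Ring Where Nothing Has Yet Registered

A few compounds are considered here, and "the series" means these few. Any claim that something is new, unique, unknown or untested is made for them only; others in the source may bear on it.

Compound 3 `Cc1noc(CN(c2ccccc2)[C@H]2c3cc(C#N)ccc3OC(C)(C)[C@@H]2O)n1` is the starting point. In a functional assay (aorta) with Rattus norvegicus as the target (a lower number here means a stronger inhibitor, a higher number a weaker inhibitor), compound 3 shows only a limit, > 30000 nM. Compound 1 `CCOC(=O)CN(c1ccccc1)[C@H]1c2cc(C#N)ccc2OC(C)(C)[C@@H]1O` also gives a limit in this assay, > 30000 nM. Compound 2 `CCOC(=O)CCCN(c1ccccc1)[C@H]1c2cc(C#N)ccc2OC(C)(C)[C@@H]1O` likewise gives a limit in this assay, > 30000 nM. The steps a step that the two limits leave unreadable from compound 1 to compound 2, a step that the two limits leave unreadable from compound 1 to compound 3 and a step that the two limits leave unreadable from compound 2 to compound 3 cannot be sized, since all three values sit at the limit of > 30000 nM in this assay, at which 3 of the 3 values shown sit. Compound 4 `Cc1cc(CN(c2ccccc2)[C@H]2c3cc(C#N)ccc3OC(C)(C)[C@@H]2O)on1` differs from compound 3 by 3-methyl-1,2-oxazol-5-yl in place of 3-methyl-1,2,4-oxadiazol-5-yl on a saturated chain carbon bound to a nitrogen on an aromatic ring. For the measured compounds named here, no measured step speaks directly to this change. Because every value sits at the limit of > 30000 nM in this assay, at which 3 of the 3 values shown sit, compound 4 is expected to stay near that limit, with an estimated step that the limit leaves unreadable from compound 3 to compound 4 that would not stand out from the scatter. The estimated value for compound 4 in this assay is 40000 nM, with a range from 10000 nM to 150000 nM.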

Compound 4, half-maximal inhibitory concentration: > 30000 nM
Compound 4: a limit, no number (the forecaster's own chance of this, stated with the estimate: 85%); the middle value lies beyond the limit too.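

Compound 4 gives > 30000 nM in this assay, which is a limit and not a number. No step among compound 1, compound 2, compound 3 and compound 4 can be read, because they all share one limit: the limit of > 30000 nM in this assay, at which 4 of the 4 values shown sit.

Which group on the shared core would give a readable value in this assay stays open.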